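From Isopropyl to Cyclopropyl on an Aromatic Nitrogen

The source may report more compounds than this note shows. Statements on the series, on what has been measured and on what is new or still open speak of the compounds shown alone.

Among the compounds with values here, in a functional assay on A549 cells (Homo sapiens) for antiproliferative activity, read by MTT assay, with a stated time of 48 h (on this read-out lower numbers stand for stronger inhibition and higher numbers for weaker inhibition), compound 1 (`COc1ccc(-c2cc3c(cn2)[nH]c(=O)n3-c2cc(OC)c(OC)c(OC)c2)cc1O`), with hydrogen on an aromatic nitrogen, gives 630 nM and holds the lowest number of the three measured so far. Compound 2 (`COc1ccc(-c2cc3c(cn2)n(C)c(=O)n3-c2cc(OC)c(OC)c(OC)c2)cc1O`), with methyl on that nitrogen, gives 3520 nM in the same test. Compound 3 (`COc1ccc(-c2cc3c(cn2)n(C(C)C)c(=O)n3-c2cc(OC)c(OC)c(OC)c2)cc1O`), with isopropyl there, gives 7210 nM and stands highest, which makes it the weakest of the three.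

Compound 4 (`COc1ccc(-c2cc3c(cn2)n(C2CC2)c(=O)n3-c2cc(OC)c(OC)c(OC)c2)cc1O`) has not yet been measured. It carries cyclopropyl in place of isopropyl on an aromatic nitrogen and is otherwise identical to compound 3.

Within the data shown here, three measured steps bear on this change. Leaving hydrogen costs the most, with a 5.6-fold higher number from compound 1 to compound 2 (0.75 log units; beyond the scatter) and an 11-fold higher number from compound 1 to compound 3 (1.06 log units; beyond the scatter) as the two cases. Going from methyl to isopropyl gives the smaller 2.0-fold higher number from compound 2 to compound 3 (0.31 log units; beyond the scatter) and is the closest guide. None of these steps compares an open group with a ring, so the guidance is indirect.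

The expected step is small and toward a lower number, namely a 1.4-fold lower number from compound 3 to compound 4 (0.16 log units; within the scatter) and possibly none beyond the scatter. For compound 4 the estimate is 5000 nM with an expected range from 2000 nM to 11000 nM at its ends.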

Compound 4, half-maximal inhibitory concentration: > 20000 nM
Compound 4: only a limit was reported; the forecaster's own chance of this, stated with the estimate: 3%; middle value at least 4.0-fold (0.60 log units) away from the limit.
By their numbers in this assay, from the lowest: compound 1; then compound 2; then compound 3. At a limit, above all of these: compound 4.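

In this assay compound 4 gives > 20000 nM, which is a limit of the assay and not a number. Isopropyl and cyclopropyl both have 3 heavy atoms, 0 hydrogen-bond donors and 0 hydrogen-bond acceptors, so this swap adds only the three-membered ring, and it still brings an at least 2.7-fold higher number from compound 3 to compound 4 (0.44 log units; beyond the scatter), something the open groups of compound 2 and compound 3 could not show. Within the data shown here, the rise seen among the earlier compounds therefore extends past them, with an at least 5.6-fold higher number from compound 2 to compound 4 (0.75 log units; beyond the scatter) and an at least 31-fold higher number from compound 1 to compound 4 (1.50 log units; beyond the scatter), and hydrogen on this nitrogen keeps the lowest number of the four compounds.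

How far the true number of compound 4 lies past its limit stays unknown, and so does the full size of these steps: the limit of > 20000 nM in this assay, at which 1 of the 4 values shown sits. What a cyclobutyl ring, an ethyl chain or a hydroxyethyl chain on this nitrogen would give remains open, so the compounds shown cannot say whether the jump belongs to rings in general or to cyclopropyl alone.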